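This account rests on a few compounds, and the source may have more. Where it says the series, first, only, none or still open, it means among the compounds named here.

Measured in an ADME assay on a cell-free system (plasma, Rattus norvegicus); on this read-out higher numbers stand for a larger free fraction and lower numbers for a smaller free fraction:
- Compound 1 `CCCS(=O)(=O)c1ccc(F)c(C#Cc2cc(Cl)ccc2OCC(=O)O)c1`: 0.004
- Compound 2 `Cc1ccc(S(=O)(=O)N(C)C(C)C)cc1C#Cc1cc(Cl)ccc1OCC(=O)O`: "not determined" (no result reported)
- Compound 3 `CC(C)c1ccc(S(C)(=O)=O)cc1C#Cc1cc(Cl)ccc1OCC(=O)O`: 0.004

Compound 2 has no standing on this scale. No number was reported for it. It therefore offers no starting value, and any view of its neighbour has to come from the other two compounds.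

That neighbour, compound 4 `Cc1ccc(S(=O)(=O)N(C)C)cc1C#Cc1cc(Cl)ccc1OCC(=O)O`, has not yet been measured. It differs from compound 2 in one place: methyl in place of isopropyl on a sulfonamide nitrogen.

Among the measured compounds shown here, no measured pair shows what such a change does in this assay, so no step can be read from the data. The best guide is the two relatives with numbers. Compound 1 gives 0.004 and compound 3 gives 0.004, even though these two structures differ from each other in more than one place. No shift beyond the scatter is expected from them, in either direction.

For compound 4 the estimated value is 0.005, with an expected range from 0.002 to 0.012.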

Compound 4, unbound fraction: 0.004
For compound 4 the middle estimate is 1.3-fold (0.10 log units) above the measured one, and the stated range covers the measured number.
By their numbers in this assay, from the lowest: compounds 1, 3 and 4 (each within the scatter of the next).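

Compound 2 has no number in this assay, so no step from it to compound 4 can be read, and nothing shown offers an explanation for the result of compound 4. As far as these compounds go, what methyl in place of isopropyl on a sulfonamide nitrogen does in this assay stays open.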